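Removing the Fluorine from the Aryl of Compound 3

The compounds below may be only part of what the source reports. "The series", "measured", "known", "first", "only" and "open" are said of these compounds alone.

Compound 3 `Cc1ccc(C)c(N2CCN(C(=O)c3oc(C)nc3-c3cccc(F)c3)CC2)c1` shows the highest number of the three measured compounds in a functional assay on HL-60 cells (Homo sapiens) for inhibition, read by MTT assay, with a stated time of 72 h (on this read-out higher numbers stand for weaker inhibition and lower numbers for stronger inhibition), giving 204 nM. Compound 1 `Cc1nc(-c2ccccc2)c(C(=O)N2CCN(c3cccc(Cl)c3Cl)CC2)o1` stands nearest, with 133 nM, a gap within the scatter, while compound 2 `Cc1nc(-c2ccccc2)c(C(=O)N2CCN(c3cccc(C#N)c3)CC2)o1` lies furthest, with 39.6 nM. Among the measured compounds shown here, the only measured step, a 3.4-fold lower number from compound 1 to compound 2 (0.53 log units; beyond the scatter), concerns the amine nitrogen in a ring, not the aryl on the core. Compound 4 `Cc1ccc(C)c(N2CCN(C(=O)c3oc(C)nc3-c3ccccc3)CC2)c1` differs from compound 3 by hydrogen in place of fluoro on an aromatic carbon; the fluoro leaves and a hydrogen enters, meta to a large group, and one bond further out this reads 3-fluorophenyl to phenyl. For the measured compounds named here, no measured step bears on this change, and compounds 1 and 2 carry phenyl here but differ elsewhere. A step of no size beyond the scatter is therefore expected, a 1.0-fold lower number from compound 3 to compound 4 (0.01 log units; within the scatter). Compound 4 is estimated at 200 nM, between 90 nM and 450 nM.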

Compound 4, half-maximal inhibitory concentration: 31.3 nM
Compound 4: the middle estimate sits 6.4-fold (0.81 log units) above what was measured, outside the stated range (below it).
By their numbers in this assay, from the lowest: compounds 4 and 2 (each within the scatter of the next); then compounds 1 and 3 (each within the scatter of the next).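

In this assay, the aryl on the core proves sensitive to this change, with 3-fluorophenyl to phenyl giving a 6.5-fold lower number from compound 3 to compound 4 (0.81 log units; beyond the scatter). With phenyl on the core and 2,5-dimethylphenyl on the amine nitrogen, the replacements give a 1.3-fold lower number from compound 2 to compound 4 (0.10 log units; within the scatter) and a 4.2-fold lower number from compound 1 to compound 4 (0.63 log units; beyond the scatter), so 2,5-dimethylphenyl stands level with 3-cyanophenyl and gives a lower number than 2,3-dichlorophenyl. No measurement here speaks to the origin of the fluoro step.

Going by these compounds, whether a methoxy or a chloro group at this place would act like the fluoro stays open. So does whether the fluoro step holds with 3-cyanophenyl on the amine nitrogen.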